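Alkoxy and aryloxy variation on a bicyclic pyridyl series

A few compounds are considered here, and "the series" means these few. Any claim that something is new, unique, unknown or untested is made for them only; others in the source may bear on it.

Measured compounds in an in vitro assay on SH-EP1 cells for displacement of a labelled ligand from Neuronal acetylcholine receptor; alpha4/beta2 (Homo sapiens); on this read-out higher numbers stand for weaker inhibition and lower numbers for stronger inhibition:
- compound 1 `C1=C(c2cncc(OCc3ccccc3)c2)CC2CNCC1C2`: 0.7 nM
- compound 2 `Clc1ccccc1Oc1cncc(C2=CC3CNCC(C2)C3)c1`: 0.9 nM
- compound 3 `Fc1ccc(Oc2cncc(C3=CC4CNCC(C3)C4)c2)cc1`: 0.6 nM

Compound 3 holds the lowest number of the three, but its steps to the other two are small: a 1.2-fold lower number from compound 1 to compound 3 (0.07 log units; within the scatter) and a 1.5-fold lower number from compound 2 to compound 3 (0.18 log units; within the scatter) both sit within the scatter, so the three compounds are not separable on this assay. The same holds for a 1.3-fold higher number from compound 1 to compound 2 (0.11 log units; within the scatter).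

Compound 4 `COc1cncc(C2=CC3CNCC(C2)C3)c1` is the next member to be measured. The change is methyl in place of 4-fluorophenyl on an oxygen on an aromatic ring. Within the data shown here, every measured step so far swaps one aromatic group on that oxygen for another, and none of them moved the number beyond the scatter. Among the measured compounds shown here, no measured pair shows what happens when the aromatic group on the oxygen is removed altogether, so the earlier steps give only indirect support. The series appears tolerant at this position, and a small loss is the most that is expected for compound 4 in this assay, given the unchanged numbers from compound 1 to compound 3 a 1.2-fold lower number from compound 1 to compound 3 (0.07 log units; within the scatter).

Compound 4 is therefore estimated at 1.5 nM in this assay, with a range from 0.3 nM to 8 nM; the expected step is a 2.5-fold higher number from compound 3 to compound 4 (0.40 log units; beyond the scatter).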

Compound 4, inhibition constant: 0.3 nM
The estimate for compound 4 lay 5.0-fold (0.70 log units) above the measured number; the measured number falls inside the stated range.
By their numbers in this assay, from the lowest: compounds 4, 3, 1 and 2 (each within the scatter of the next, the first and the last beyond it).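

In this assay the aromatic group on the oxygen proves not to be required: methyl in place of 4-fluorophenyl stays within the scatter (a 2.0-fold lower number from compound 3 to compound 4 (0.30 log units; within the scatter)). Against the other two aromatic groups, the loss of the ring gives modest steps beyond the scatter, toward lower numbers (a 3.0-fold lower number from compound 2 to compound 4 (0.48 log units; beyond the scatter) for methyl in place of 2-chlorophenyl; a 2.3-fold lower number from compound 1 to compound 4 (0.37 log units; beyond the scatter) for hydrogen in place of phenyl on the saturated chain carbon bound to the oxygen). The earlier steps shown here only exchanged one aromatic group for another, so the tolerance at this position now extends to a group of 1 heavy atom, with no loss on these numbers. No measurement at hand offers an explanation for this result.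

Open, from the compounds shown here alone, is how far this tolerance runs between methyl and the aromatic groups, for example with an ethyl or a longer chain on the oxygen. Also open, going by these compounds, is whether an amine or a carboxylic acid at the end of such a chain would be accepted in this assay as well.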